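This account rests on a few compounds, and the source may have more. Where it says the series, first, only, none or still open, it means among the compounds named here.

Three compounds share one core and differ only in the group on the aromatic nitrogen. In a functional assay on the whole organism with Rattus norvegicus as the target, in the maximal electroshock model (a lower number here means that less compound is needed, a higher number that more compound is needed for the effect), compound 1 `CCCNc1ncnc2c1ncn2Cc1ccccc1F` gives 5.1 mg/kg. Compound 3 `Fc1ccccc1Cn1cnc2c(NCC3CC3)ncnc21` gives 4.3 mg/kg in this assay, and the step of a 1.2-fold lower number from compound 1 to compound 3 (0.07 log units; within the scatter) places the two side by side. Compound 2 `CC(C)(C)Nc1ncnc2c1ncn2Cc1ccccc1F` reaches only a limit, > 50 mg/kg, in this assay. The steps of an at least 9.8-fold higher number from compound 1 to compound 2 (0.99 log units; beyond the scatter) and an at least 11-fold lower number from compound 2 to compound 3 (1.06 log units; beyond the scatter) show that a tert-butyl on that nitrogen costs much. Among the measured compounds shown here, compound 4 `Fc1ccccc1Cn1cnc2c(N3CCCC3)ncnc21` carries the change (pyrrolidin-1-yl in place of (cyclopropylmethyl)amino on an aromatic carbon); no measured step covers a nitrogen closed into a ring, and the nearest comparison is the costly change in compound 2. Compound 4 is therefore expected to need more, about 20 mg/kg, between 6 mg/kg and 60 mg/kg, possibly only a limit. The expected step is a 4.7-fold higher number from compound 3 to compound 4 (0.67 log units; beyond the scatter).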

Compound 4, dose for half-maximal effect: 12.5 mg/kg
Beside the measured number, compound 4's estimate is 1.6-fold (0.20 log units) above it; low and high end bracket the measured number.
By their numbers in this assay, from the lowest: compounds 3 and 1 (each within the scatter of the next); then compound 4. At a limit, above all of these: compound 2.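

A nitrogen closed into a ring, as in pyrrolidin-1-yl with 0 hydrogen-bond donors, costs only modestly in this assay: the data show a 2.9-fold higher number from compound 3 to compound 4 (0.46 log units; beyond the scatter) and a 2.5-fold higher number from compound 1 to compound 4 (0.39 log units; beyond the scatter). This group still does better than (tert-butyl)amino, with an at least 4.0-fold lower number from compound 2 to compound 4 (0.60 log units; beyond the scatter), so a hydrogen-bond donor on this nitrogen is not essential for the effect. Compound 2 remains a limit of the assay: the limit of > 50 mg/kg in this assay, at which 1 of the 4 values shown sits.

From the compounds shown here alone, whether the modest cost comes from the missing donor or from the ring itself stays open. A dimethylamino group, which has no ring and no donor, would separate the two, and piperidine or morpholine would show how much ring this place accepts.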